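The source may hold more compounds than are shown below. What is called first, only, known or untested is meant among the compounds shown, and "the series" means these compounds.

Measured compounds:
compound 1 `CCCOC(=O)C1=C(C)N(C)C(=O)NC1c1ccoc1` with 1%
compound 2 `CC1=C(C(=O)OCC(C)C)C(c2ccoc2)NC(=O)N1C` with 4%
compound 3 `CC1=C(C(=O)OC(C)(C)C)C(c2ccoc2)NC(=O)N1C` with 21%

These three compounds share one core and differ only in the ester group attached to it. They were tested in an assay on membranes from CHO cells for displacement of a labelled ligand from adenosine receptor A1 (Homo sapiens), read by scintillation counting, with a stated time of 60 min, tested at 1 uM; on this read-out lower numbers stand for less inhibition and higher numbers for more inhibition at the one concentration tested (going by the name of the read-out). Compound 2 holds the second highest of the three numbers. Its nearest neighbour is compound 1, and the step of a number 3 percentage points higher from compound 1 to compound 2 (within the scatter) is too small to count as a real difference. Its furthest neighbour is compound 3, and the step of a number 17 percentage points higher from compound 2 to compound 3 (beyond the scatter) is large enough to stand out from the scatter, as is the step of a number 20 percentage points higher from compound 1 to compound 3 (beyond the scatter).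

Compound 4 `CC1=C(C(=O)OCC(C)C)C(c2ccsc2)NC(=O)N1C` keeps the isobutyl ester of compound 2 and changes a different part of the molecule: thiophen-3-yl in place of furan-3-yl on a saturated ring carbon. Among the measured compounds shown here, none of the measured steps touches this ring; all of them alter the ester or its chain, so there is no direct precedent for exchanging the furan-3-yl for a thiophen-3-yl. With nothing pointing up or down, the expectation is a step of a number 4 percentage points higher from compound 2 to compound 4 (within the scatter) that stays within the scatter. Compound 4 is therefore estimated to give 8% in this assay, with a plausible range from 0% to 25%.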

Compound 4, a percentage reported as inhibition, at one concentration (the size of the read-out at that concentration, not a potency): 8%
Beside the measured number, compound 4's estimate shows no gap at the digits printed; measured number inside the range.
By their numbers in this assay, from the lowest: compounds 1, 2 and 4 (each within the scatter of the next); then compound 3.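

Among the compounds shown here, until now every measured step altered the ester, so this is the first reading at the saturated ring carbon that carries the five-membered aromatic ring. With the isobutyl ester held fixed, this assay shows a number 4 percentage points higher from compound 2 to compound 4 (within the scatter) for thiophen-3-yl in place of furan-3-yl, so no real difference can be claimed for this exchange, in which sulfur takes the place of oxygen while the heavy-atom count, the hydrogen-bond counts and the lack of net charge stay the same. Nothing measured on these compounds offers an explanation for this result, and this reading covers only one concentration and one ester.

For the compounds shown here, open is whether thiophen-3-yl and furan-3-yl would also match alongside the tert-butyl ester of compound 3, the only compound whose steps to the others lie beyond the scatter. Also open, going by these compounds, is whether a more different group at this ring carbon, such as a phenyl group or a ring bearing a carboxylic acid, would move the number beyond the scatter.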